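Swapping the amine arm on a macrocyclic enone

A few compounds are considered here, and "the series" means these few. Any claim that something is new, unique, unknown or untested is made for them only; others in the source may bear on it.

Of the compounds shown here, three sharing one large-ring core have been tested in a functional assay on SW480 cells (Homo sapiens) for antiproliferative activity, read by MTT assay, with a stated time of 48 h; on this read-out higher numbers stand for weaker inhibition and lower numbers for stronger inhibition. Compound 1 `CC(=O)O[C@]1(C)/C=C/C(=O)/C(CO)=C\C[C@](C)(CCC=C(C)C)/C=C/[C@H]1OC(=O)C=C(C)C` gives 2010 nM. Going by the values given here, compound 2 `CO[C@]1(C)/C=C/C(=O)/C(CO)=C\C[C@](C)(CCC=C(C)C)/C=C/[C@H]1OC(=O)C=C(C)C` gives 15200 nM, and the only single-point change among the measured compounds, a 7.6-fold higher number from compound 1 to compound 2 (0.88 log units; beyond the scatter), sits on an oxygen far from the ring position of interest here. Compound 3 `CCN(CC)C/C1=C/C[C@](C)(CCC=C(C)C)/C=C/[C@@H](OC(=O)C=C(C)C)[C@](C)(O)/C=C/C1=O` gives 270 nM in this assay, the lowest of the three numbers and therefore the strongest inhibitor, with compound 1 nearest and compound 2 furthest away.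

Compound 4 `CO/N=C/C1=C/C[C@](C)(CCC=C(C)C)/C=C/[C@@H](OC(=O)C=C(C)C)[C@](C)(O)/C=C/C1=O` differs from compound 3 in one place: a group of 4 heavy atoms (2 carbon, 1 nitrogen, 1 oxygen; no ring) in place of a group of 6 heavy atoms (5 carbon, 1 nitrogen; no ring), on a double-bonded ring carbon. Among the compounds with values here, no measured step concerns this ring position, so the expectation rests only on the spread of the three values, from compound 3 up to compound 2. Because compound 3 gives 270 nM and compound 1, which carries only a hydroxymethyl at that ring carbon, gives 2010 nM, compound 4 is estimated to land between them, with a step of a 5.6-fold higher number from compound 3 to compound 4 (0.74 log units; beyond the scatter) expected. Compound 4 is thus expected to show 1500 nM, within 300 nM to 6000 nM.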

Compound 4, half-maximal inhibitory concentration: 2630 nM
Estimate against measurement, compound 4: 1.8-fold (0.24 log units) below; low and high end bracket the measured number.
By their numbers in this assay, from the lowest: compound 3; then compounds 1 and 4 (each within the scatter of the next); then compound 2.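

The earlier compounds shown here gave no step at this double-bonded ring carbon; in this assay, exchanging (diethylamino)methyl for the smaller group of 4 heavy atoms now provides one, a 9.7-fold higher number from compound 3 to compound 4 (0.99 log units; beyond the scatter), meaning weaker inhibition. The group at this carbon therefore affects the read-out while the rest of compound 3 stays the same, although a single step cannot separate the effect of group size from that of the atoms the group contains. Nothing available here explains the change.

From the compounds shown here alone, it remains open whether the diethylamino part itself is needed, or whether a dimethylamino or morpholine group on the same methyl carbon would give a similar number. A longer chain ending in a diethylamino group is also untested by the compounds shown, so how far this position tolerates change remains unknown.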